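This account rests on a few compounds, and the source may have more. Where it says the series, first, only, none or still open, it means among the compounds named here.

In a functional assay on the whole organism for inhibition, with Cavia porcellus as the target (on this read-out lower numbers stand for an effect already at smaller amounts and higher numbers for an effect only at larger amounts of compound), compound 1 `COc1ccccc1OCC1SCCN1C(=O)CC(=O)O` gives 20 mg/kg and compound 2 `CCOC(=O)C(C)(C)C(=O)N1CCSC1COc1ccccc1OC` gives 61 mg/kg, the higher of the two numbers. Compound 3 `CNC(=O)CC(=O)N1CCSC1COc1ccccc1OC` carries (methylcarbamoyl)methyl in place of 1-(ethoxycarbonyl)-1-methylethyl on a carbonyl carbon. Going by the values given here, one measured step bears on this change, a modest one: a 3.1-fold higher number from compound 1 to compound 2 (0.48 log units; beyond the scatter). Among the compounds with values here, that step brought in the group now leaving, and no measurement yet covers the entering group. A modest step toward a lower number is therefore expected in this assay, no larger than the measured one. The estimated step is a 2.0-fold lower number from compound 2 to compound 3 (0.31 log units; beyond the scatter). For compound 3 the expected value is 30 mg/kg, with an estimated range of 10 mg/kg to 85 mg/kg.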

Compound 3, dose for half-maximal effect: 21 mg/kg
For compound 3 the middle estimate is 1.4-fold (0.15 log units) above the measured one; measured number inside the range.
By their numbers in this assay, from the lowest: compounds 1 and 3 (each within the scatter of the next); then compound 2.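

In this assay, (methylcarbamoyl)methyl in place of 1-(ethoxycarbonyl)-1-methylethyl gives a 2.9-fold lower number from compound 2 to compound 3 (0.46 log units; beyond the scatter) and so the higher number of compound 2 does not extend to every group at this place. Methylamino in place of hydroxy on a carbonyl carbon gives a 1.1-fold higher number from compound 1 to compound 3 (0.02 log units; within the scatter) and so this exchange leaves no difference beyond the scatter. Still open, on these data alone, is whether the ethyl ester or the methyl branching of 1-(ethoxycarbonyl)-1-methylethyl goes with the higher number, which unbranched ethoxycarbonylmethyl would help separate. No measured property accounts for these steps.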